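The compounds below may be only part of what the source reports. "The series", "measured", "known", "first", "only" and "open" are said of these compounds alone.

Of the compounds shown here, two of one series have been measured in a functional assay on SN12C cells (Homo sapiens) for inhibition, read by sulforhodamine B assay, with a stated time of 48 h; on this read-out lower numbers stand for stronger inhibition of growth and higher numbers for weaker inhibition of growth. Compound 1, `COc1ccc(-c2cc(/C=C/C(=O)c3ccc(N)cc3)[nH]n2)cc1`, carries one methoxy group on its six-membered aromatic ring of carbon only, and in this assay compound 1 gives 6630 nM. Compound 2, `COc1cc(-c2cc(/C=C/C(=O)c3ccc(N)cc3)[nH]n2)cc(OC)c1OC`, carries three methoxy groups on that ring, and in this assay compound 2 gives 4520 nM. Compound 2 holds the lowest of the two numbers, yet its gap to compound 1 is within the usual scatter of such measurements, so the two cannot be told apart on these data. Compound 3, `COc1ccc(-c2cc(/C=C/C(=O)c3ccc(N)cc3)[nH]n2)cc1OC`, is not yet measured. It differs from compound 2 in one place: hydrogen in place of methoxy on an aromatic carbon. For the measured compounds named here, no step between two measured compounds shows what such a change does here, and the two measured values themselves differ by less than the scatter. In this assay a step of no more than the scatter, in either direction, is expected. Compound 3 is therefore estimated at 5000 nM, with a likely range from 2500 nM to 10000 nM. The expected step is a 1.1-fold higher number from compound 2 to compound 3 (0.04 log units; within the scatter).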

Compound 3, concentration for total growth inhibition: 13700 nM
Beside the measured number, compound 3's estimate is 2.7-fold (0.44 log units) below it; measured number outside the range, above it.
By their numbers in this assay, from the lowest: compounds 2 and 1 (each within the scatter of the next); then compound 3.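

Removing the methoxy that is ortho to a methoxy group and meta to a large group is not a silent change in this assay: it gives a 3.0-fold higher number from compound 2 to compound 3 (0.48 log units; beyond the scatter) and so counts as a modest loss of growth inhibition. Adding a methoxy in place of hydrogen also ends at compound 3, with a 2.1-fold higher number from compound 1 to compound 3 (0.32 log units; beyond the scatter) as another modest step toward weaker inhibition, so gaining one methoxy and losing one both lead to the same weaker compound, and the number of methoxy groups alone does not order these compounds. No measurement given here accounts for this behaviour.

As far as these compounds go, it remains open whether a fluorine atom, a hydroxy group or an ethoxy group on that same aromatic carbon would behave more like the hydrogen of compound 3 or the methoxy of compound 2. From the compounds shown here alone, these compounds also vary only the methoxy groups, so it is unknown whether the same steps would appear if the amine on the shared core were replaced by an amide.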